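Swapping tert-butoxy on a carbonyl carbon

The source may hold more compounds than are shown below. What is called first, only, known or untested is meant among the compounds shown, and "the series" means these compounds.

Of the compounds shown here, three sharing one core have been measured in a physicochemical assay for solubility, in phosphate buffer, at pH 6.5; on this read-out higher numbers stand for higher solubility and lower numbers for lower solubility. Compound 1 (`C=C[C@@H]1C[C@]1(NC(=O)[C@@H]1C[C@@H](Oc2nccc3cc(OC)ccc23)CN1C(=O)[C@@H](NC(=O)N[C@@H](CC)COC)C(C)(C)C)C(=O)NS(=O)(=O)C1CC1`) gives 500 ug/mL and compound 2 (`C=C[C@@H]1C[C@]1(NC(=O)[C@@H]1C[C@@H](Oc2nccc3cc(OC)ccc23)CN1C(=O)[C@@H](NC(=O)N[C@H](COC)C(C)(C)C)C(C)(C)C)C(=O)NS(=O)(=O)C1CC1`) gives 609 ug/mL. The step between them is a 1.2-fold higher number from compound 1 to compound 2 (0.09 log units; within the scatter). Compound 3 (`C=C[C@@H]1C[C@]1(NC(=O)[C@@H]1C[C@@H](Oc2nccc3cc(OC)ccc23)CN1C(=O)[C@@H](NC(=O)N[C@H](C(=O)OC(C)(C)C)C(C)(C)C)C(C)(C)C)C(=O)NS(=O)(=O)C1CC1`) stands lowest of the three, at 1 ug/mL. The two measured steps that reach it are a 500-fold lower number from compound 1 to compound 3 (2.70 log units; beyond the scatter) and a 610-fold lower number from compound 2 to compound 3 (2.78 log units; beyond the scatter), and both are large.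

The next structure is compound 4 (`C=C[C@@H]1C[C@]1(NC(=O)[C@@H]1C[C@@H](Oc2nccc3cc(OC)ccc23)CN1C(=O)[C@@H](NC(=O)N[C@H](C(=O)N1CCN(c2ncccn2)CC1)C(C)(C)C)C(C)(C)C)C(=O)NS(=O)(=O)C1CC1`), with 4-(pyrimidin-2-yl)piperazin-1-yl in place of tert-butoxy on a carbonyl carbon. For the measured compounds named here, no measured step makes this exact exchange, so the evidence is indirect. The step of a 610-fold lower number from compound 2 to compound 3 (2.78 log units; beyond the scatter) shows that the number can move widely when tert-butoxycarbonyl takes the place of methoxymethyl, and that step brought in both the tert-butoxy and the carbonyl. Compound 4 loses the tert-butoxy but keeps the carbonyl, so only a partial return towards compound 2 at 609 ug/mL is expected. The expected change in this assay is a 20-fold higher number from compound 3 to compound 4 (1.30 log units; beyond the scatter), upward and beyond the scatter, yet smaller than the measured drops. For compound 4 the estimate is 20 ug/mL, with an expected range from 2 ug/mL to 200 ug/mL.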

Compound 4, solubility: 132 ug/mL
For compound 4 the middle estimate is 6.6-fold (0.82 log units) below the measured one, within the range that was stated.
By their numbers in this assay, from the lowest: compound 3; then compound 4; then compounds 1 and 2 (each within the scatter of the next).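

In this assay the exchange gives a 130-fold higher number from compound 3 to compound 4 (2.12 log units; beyond the scatter) and leaves the carbonyl in place, so the very low number of compound 3 does not follow from the carbonyl alone: at this position, the group on the carbonyl carbon can by itself move the read-out widely. The entering 4-(pyrimidin-2-yl)piperazin-1-yl is also the larger group, with 12 heavy atoms and two rings against 5 heavy atoms and no ring for tert-butoxy, and here the greater size goes with the higher number, in this one pair only. Nothing measured here accounts for the rise.

On these data alone, whether the rise belongs to the piperazine ring, to the pyrimidine on it or simply to the loss of tert-butoxy stays open, since the entering group brings them together in one exchange. It also remains to be seen how the number would respond to a simple piperidine or dimethylamino group on the same carbonyl carbon, or to the free carboxylic acid.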